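Arylmethyl variation in a formyl peptide receptor 3 series

A few compounds are considered here, and "the series" means these few. Any claim that something is new, unique, unknown or untested is made for them only; others in the source may bear on it.

Measured so far:
compound 1 `Cc1cc(Cc2ccsc2)c(=O)n(CC(=O)Nc2ccc(Br)cc2)n1`: > 50000 nM
compound 2 `Cc1cc(Cc2cccs2)c(=O)n(CC(=O)Nc2ccc(Br)cc2)n1`: 10200 nM

In an assay on HL-60 cells for agonist activity at N-formyl peptide receptor 3 (Homo sapiens), read by calcium flux (a lower number here means that less compound is needed, a higher number that more compound is needed for the effect), compound 1 reaches only the assay limit, > 50000 nM (the limit of > 50000 nM in this assay, at which 1 of the 2 values shown sits). Within the data shown here, compound 2 gives 10200 nM, the only number so far, with an at least 4.9-fold lower number from compound 1 to compound 2 (0.69 log units; beyond the scatter).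

Compound 3 `Cc1cc(Cc2cccc3ccccc23)c(=O)n(CC(=O)Nc2ccc(Br)cc2)n1` differs from compound 2 by naphthalen-1-yl in place of thiophen-2-yl on a saturated chain carbon bound to an aromatic carbon. Among the measured compounds shown here, the one measured step, an at least 4.9-fold lower number from compound 1 to compound 2 (0.69 log units; beyond the scatter), concerns the attachment point of the thiophene ring and gives no guide to a larger aromatic group; no measured step bears directly on this change. For the measured compounds named here, a modest step in either direction is therefore expected, not beyond what the single step shows. Compound 3 is expected at 8000 nM, range 1500 nM to 40000 nM. This corresponds to an expected step of a 1.3-fold lower number from compound 2 to compound 3 (0.11 log units; within the scatter).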

Compound 3, half-maximal effective concentration: > 50000 nM
Compound 3 gave a limit, no number; the forecaster's own chance of this, stated with the estimate: 30%; middle value at least 6.2-fold (0.79 log units) away from the limit.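

In this assay, naphthalen-1-yl in place of thiophen-2-yl on a saturated chain carbon bound to an aromatic carbon brings an at least 4.9-fold higher number from compound 2 to compound 3 (0.69 log units; beyond the scatter). Compound 3 gives a limit of the assay, > 50000 nM, not a number. The step between compound 1 and compound 3 cannot be read, and thiophen-2-yl remains the only group at this place to give a number: the limit of > 50000 nM in this assay, at which 2 of the 3 values shown sit.

Open, on these data alone, is whether a plain phenyl group at this place gives a number in this assay. Also open, as far as these compounds go, is whether an amine or a carboxylic acid on the thiophene ring of compound 2 would lower its number.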